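A few compounds are considered here, and "the series" means these few. Any claim that something is new, unique, unknown or untested is made for them only; others in the source may bear on it.

Working notes, compound 2 to compound 4. Compound 2 `COc1cc([C@](O)(CCN(C)C)[C@@H](c2cc3cc(Br)ccc3nc2OC)c2ccnc(OC)c2OC)cc(OC(C)C)n1` gives 6.4 uL/min in an ADME assay on microsomes from liver (Homo sapiens) for metabolic stability (a higher number here means faster removal of the compound, a lower number slower removal), the highest of the three numbers shown. Compound 1 `COc1cc([C@](O)(CCN(C)C)[C@@H](c2cc3cc(Br)ccc3nc2OC)c2cccc(OC)c2F)cc(OC(C)C)n1` gives 3.4 uL/min, and the step of a 1.9-fold higher number from compound 1 to compound 2 (0.27 log units; within the scatter) lies within the scatter. Among the measured compounds shown here, compound 3 `COc1cc([C@](O)(CCN(C)C)[C@@H](c2cc3cc(C#N)ccc3nc2OC)c2cccc(C)c2F)cc(OC(F)F)n1` gives 0.6 uL/min, a lower number than compound 2, beyond the scatter, but compound 3 differs from compound 2 in several places and no single step links them. Compound 4 `COc1cc([C@](O)(CCN(C)C)[C@@H](c2cc3cc(Br)ccc3nc2OC)c2ccnc(OC)c2OC)cc(OC(F)F)n1` carries the change (difluoromethyl in place of isopropyl on an oxygen on an aromatic ring). For the measured compounds named here, no measured step bears on this change alone; compound 3 is the only compound with a difluoromethoxy group, and its gap to compound 2 cannot be assigned to that group. The expected step of a 1.4-fold lower number from compound 2 to compound 4 (0.15 log units; within the scatter) is therefore small, if anything a lower number. For compound 4 the estimate is 4.5 uL/min, with a range of 2 uL/min to 10 uL/min.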

Compound 4, intrinsic clearance in a liver preparation (reported as CLH), per the amount of preparation that the assay uses: 2.1 uL/min
Compound 4: middle estimate off by 2.1-fold (0.33 log units), on the high side; the range from low to high includes it.
By their numbers in this assay, from the lowest: compound 3; then compounds 4, 1 and 2 (each within the scatter of the next, the first and the last beyond it).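

In this assay, among the compounds shown here, the change from isopropoxy to difluoromethoxy, on an oxygen on an aromatic ring, gives a 3.0-fold lower number from compound 2 to compound 4 (0.48 log units; beyond the scatter), the first step that reads this position alone. The change in heavy atoms is confined to the swap of isopropyl for difluoromethyl, so the step belongs to that one place. No measurement bearing on the origin of this step is available. The compounds shown leave open whether the same step holds with the 2-fluoro-3-methoxyphenyl of compound 1 in place of the 2,3-dimethoxypyridin-4-yl. From the compounds shown here alone, how a methyl or a trifluoromethyl on this oxygen would compare also stays open.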